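Aryl variation on the shared core with weak growth inhibition

The source may hold more compounds than are shown below. What is called first, only, known or untested is meant among the compounds shown, and "the series" means these compounds.

Compound 1, `Cc1cc(Cl)ccc1Nc1ncc(C(F)(F)F)c(N2Cc3cccc(N(C)S(C)(=O)=O)c3C2)n1`: 25500 nM in a functional assay on A549 cells (Homo sapiens) for antiproliferative activity, read by spectrophotometry, with a stated time of 2 days; on this read-out lower numbers stand for stronger inhibition of growth and higher numbers for weaker inhibition of growth.
Compound 2, `CN(c1cccc2c1CN(c1nc(Nc3ccc(C(F)(F)F)cc3)ncc1C(F)(F)F)C2)S(C)(=O)=O`: > 30000 nM in this assay, a limit of the assay.
Compound 3, `CN(c1cccc2c1CN(c1nc(Nc3ccc(Cl)c(C(F)(F)F)c3)ncc1C(F)(F)F)C2)S(C)(=O)=O`: 15200 nM in this assay.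

Compound 3 holds the lowest of the two numbers, yet compound 1 lies within the scatter of it, a 1.7-fold lower number from compound 1 to compound 3 (0.22 log units; within the scatter). Compound 2 reports only a limit in this assay (the limit of > 30000 nM in this assay, at which 1 of the 3 values shown sits). The other aryl exchanges are likewise unresolved: an at least 1.1-fold higher number from compound 1 to compound 2 (0.07 log units; that floor lies within the scatter) and an at least 1.9-fold lower number from compound 2 to compound 3 (0.29 log units; that floor lies within the scatter). Compound 4, `COc1ccc(C(F)(F)F)cc1Nc1ncc(C(F)(F)F)c(N2Cc3cccc(N(C)S(C)(=O)=O)c3C2)n1`, is the next variation at the same position: 2-methoxy-5-(trifluoromethyl)phenyl in place of 4-chloro-3-(trifluoromethyl)phenyl on a nitrogen on an aromatic ring. Three aryl groups have given no step beyond the scatter, so compound 4 is expected to stay near compound 3, with a 1.3-fold higher number from compound 3 to compound 4 (0.12 log units; within the scatter). Compound 4 is estimated at 20000 nM, in the range 8000 nM to 45000 nM.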

Compound 4, concentration for 50% growth inhibition: > 30000 nM
Compound 4 was reported as a limit; the forecaster's own chance of this, stated with the estimate: 30%; middle value at least 1.5-fold (0.17 log units) from the limit.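

Compound 4 is reported only as a limit in this assay: the limit of > 30000 nM in this assay, at which 2 of the 4 values shown sit.

For the compounds shown here, the 2-methoxy-5-(trifluoromethyl)phenyl group, the first aryl group here to carry an oxygen, gives an at least 1.9-fold higher number from compound 3 to compound 4 (0.29 log units; that floor lies within the scatter) and an at least 1.1-fold higher number from compound 1 to compound 4 (0.07 log units; that floor lies within the scatter), so a fourth aryl group on this nitrogen still shows no step beyond the scatter. The step between the two compounds at the limit cannot be read.

As far as these compounds go, whether any aryl group at this position can give a step beyond the scatter stays open. So does the reading for an aryl group bearing an amine or a carboxylic acid.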